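The source may hold more compounds than are shown below. What is called first, only, known or untested is meant among the compounds shown, and "the series" means these compounds.

Compound 2 `Cc1ccoc1C1C(C#N)=C(N)N(c2ccc(S(N)(=O)=O)cc2)C2=C1C(=O)CCC2` gives 40% in a functional assay on Ehrlich cells (Mus musculus) for antiproliferative activity, read by trypan blue exclusion, with a stated time of 2 h, tested at 50 ug/mL (on this read-out lower numbers stand for a weaker effect and higher numbers for a stronger effect at the one concentration tested), and so stands lowest of the two numbers measured; the nearest is compound 1 `COc1ccc2ccccc2c1C1C(C#N)=C(N)N(c2ccc(S(N)(=O)=O)cc2)C2=C1C(=O)CCC2`, which gives 70% in this assay. For the measured compounds named here, the one measured step, a number 30 percentage points lower from compound 1 to compound 2 (beyond the scatter), changes the same saturated ring carbon that the next step touches: a larger bicyclic aromatic group gives way to a smaller five-membered one, and the read-out falls beyond the scatter.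

Compound 3 `N#CC1=C(N)N(c2ccc(S(N)(=O)=O)cc2)C2=C(C(=O)CCC2)C1c1cccs1` differs from compound 2 at that position: thiophen-2-yl in place of 3-methylfuran-2-yl on a saturated ring carbon. The group that leaves and the group that enters are each a single five-membered aromatic ring with one hetero atom, so the change is far smaller than the one already measured. Going by the values given here, no measured step shows a swap between two five-membered rings of this kind, so the size and direction of the effect are uncertain; the one step that bears on it only shows that this position is sensitive.

For compound 3 a step of no change at the digits printed from compound 2 to compound 3 (within the scatter) is expected, within the scatter, with an estimate of 40% in this assay, ranging from 20% to 60%.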

Compound 3, a percentage reported as activity, at one concentration (the size of the read-out at that concentration, not a potency): 88%
Compound 3: the middle estimate sits 48 percentage points below what was measured; measured number above the stated range.
By their numbers in this assay, from the lowest: compound 2; then compound 1; then compound 3.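

In this assay, this position separates even two single five-membered aromatic rings with one hetero atom: a number 48 percentage points higher from compound 2 to compound 3 (beyond the scatter), so a swap of this kind at the saturated ring carbon can move the read-out strongly. The earlier pair could be read as a larger group at this carbon giving the higher number, but compound 3 goes against that reading: a number 18 percentage points higher from compound 1 to compound 3 (beyond the scatter), with thiophen-2-yl in place of 2-methoxynaphthalen-1-yl, while compound 2, with 3-methylfuran-2-yl, remains the lowest of the three, so heavy-atom count alone does not order this series. No supporting measurement is available to account for these differences.

The step from compound 2 to compound 3 changes the hetero atom and removes the methyl group together, so the compounds shown cannot assign the rise to either change; furan-2-yl and 3-methylthiophen-2-yl at this carbon would separate the two. Also open, going by these compounds, is whether the read-out depends on the ring itself, as a phenyl group or a 3-thienyl isomer at the same carbon would show, and all of this rests on a single concentration.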